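Removing the chloro group from compound 3

The compounds below may be only part of what the source reports. "The series", "measured", "known", "first", "only" and "open" are said of these compounds alone.

Measured in a functional assay on thoracic aorta (Rattus norvegicus, strain Wistar), with a stated time of 15 min; a lower number here means that less compound is needed, a higher number that more compound is needed for the effect:
- compound 1 `CCOc1ccc(F)cc1C(C)NC(=O)NS(=O)(=O)c1ccc(Cl)cc1`: > 300000 nM
- compound 2 `COc1ccc(Br)cc1C(C)NC(=O)NS(=O)(=O)c1ccc(C)cc1`: > 300000 nM
- compound 3 `COc1ccc(OC)c(CNC(=O)NS(=O)(=O)c2ccc(Cl)cc2)c1`: > 300000 nM

Compound 3 gives > 300000 nM in this assay, and this is a limit of the assay, not a number. It offers no exact starting point, and the two other measured compounds give limits too. All three share one reading: the limit of > 300000 nM in this assay, at which 3 of the 3 values shown sit.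

Compound 4 `COc1ccc(OC)c(CNC(=O)NS(=O)(=O)c2ccccc2)c1` differs from compound 3 in one place, with hydrogen in place of chloro on an aromatic carbon, para to a large group (hydrogen in place of chloro on an aromatic carbon). In words of the whole group, 4-chlorophenyl becomes phenyl.

Among the compounds with values here, no measured pair of compounds shows what this change does, so the expectation rests on the limit alone. The expected change in this assay is none beyond the usual scatter, in either direction, and the assay may well report only a limit again. The estimated step is an at least 1.5-fold lower number from compound 3 to compound 4 (0.17 log units; that floor lies within the scatter). For compound 4 the estimate is 200000 nM, with an expected range from 50000 nM to 300000 nM.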

Compound 4, half-maximal effective concentration: > 300000 nM
Compound 4: only a limit was reported; the forecaster's own chance of this, stated with the estimate: 70%; middle value at least 1.5-fold (0.17 log units) from the limit.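

In this assay compound 4 gives > 300000 nM, which is a limit and not a number. Compound 3 also has only a limit, so no step can be read between the two. The compounds shown leave open what changing 4-chlorophenyl to phenyl does, and which compound would give a readable number, as every result so far is the same: the limit of > 300000 nM in this assay, at which 4 of the 4 values shown sit.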